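A few compounds are considered here, and "the series" means these few. Any claim that something is new, unique, unknown or untested is made for them only; others in the source may bear on it.

Working notes on the series. The shared core is shown in compound 1 `C=CC(=O)Nc1cccc(-n2c(-c3nc(-c4cnn(C5CCN(CC)CC5)c4)cnc3N)nc3ccccc32)c1`, which carries an ethyl on the ring amine nitrogen. In a physicochemical assay for solubility, at pH 7.4 (a higher number here means a more soluble compound, a lower number a less soluble compound), compound 1 gives < 10000 nM, a limit of the assay rather than a number. Compound 2 `C=CC(=O)Nc1cccc(-n2c(-c3nc(-c4cnn(C5CCN(C(C)=O)CC5)c4)cnc3N)nc3ccccc32)c1` carries an acetyl in place of that ethyl. The measured step is a step that the two limits leave unreadable from compound 1 to compound 2. In this assay compound 2 gives < 10000 nM, again a limit and not a number. Among the measured compounds shown here, compound 2 therefore stands only at the edge of what this assay reports; (the limit of < 10000 nM in this assay, at which 2 of the 2 values shown sit), so no step in this set has a readable size. Compound 3 `C=CC(=O)Nc1cccc(-n2c(-c3nc(-c4cnn(C5CCN(C(=O)CN(C)C)CC5)c4)cnc3N)nc3ccccc32)c1` is the next compound, and the change from compound 2 is dimethylamino in place of hydrogen on a saturated chain carbon bound to a carbonyl carbon. For the measured compounds named here, only the step from compound 1 to compound 2 bears on it, and that step is unreadable, so no direction beyond the scatter can be taken from the measured compounds for this assay. The estimate for compound 3 in this assay is 8000 nM, with a range from 2000 nM to 30000 nM, most likely again returned as a limit. The step from compound 2 to compound 3 is expected at a step that the limit leaves unreadable from compound 2 to compound 3, within the scatter as far as the limits allow.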

Compound 3, solubility: 18000 nM
For compound 3 the middle estimate is 2.3-fold (0.35 log units) below the measured one, and the stated range covers the measured number.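

In this assay compound 3 gives 18000 nM, a number and not a limit, which makes it the only compound shown with a readable value: the limit of < 10000 nM in this assay, at which 2 of the 3 values shown sit. Placing dimethylamino in place of hydrogen on a saturated chain carbon bound to a carbonyl carbon gives an at least 1.8-fold higher number from compound 2 to compound 3 (0.25 log units; that floor lies within the scatter), and the change that starts from the ethyl group gives an at least 1.8-fold higher number from compound 1 to compound 3 (0.25 log units; that floor lies within the scatter). As far as these compounds go, both steps are floors, so their true sizes remain unknown, and the step that involves only the two limits cannot be read.

Still open, from the compounds shown here alone, is whether the readable number is specific to dimethylamino or would also appear with another group on this chain carbon, such as a morpholine, a carboxylic acid or a longer chain carrying the same amine. Also open, going by these compounds, is how far compound 1 and compound 2 actually lie from compound 3, since each of those two compounds is known here only through a limit, and a real number for either would be needed to tell whether these steps exceed the scatter.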